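The source may hold more compounds than are shown below. What is called first, only, known or untested is meant among the compounds shown, and "the series" means these compounds.

Measured compounds in a functional assay on RKO cells (Homo sapiens) for inhibition, read by MTT assay, with a stated time of 48 h; a lower number here means a stronger inhibitor, a higher number a weaker inhibitor:
compound 1 `COc1ccc(N(C)c2nc(C)nc3ccccc23)cc1C(=O)NCC[Se]C#N` gives 1170 nM;
compound 2 `COc1ccc(N(C)c2nc(C)nc3ccccc23)cc1C(=O)OCCCCC[Se]C#N` gives 356 nM;
compound 3 `C[Se]c1ccc(N(C)c2nc(C)nc3ccccc23)cc1C` gives 8 nM.

Compound 1 stands at the highest number of the three; its nearest neighbour is compound 2, and compound 3 lies far below it. Compound 4 `COc1ccc(N(C)c2nc(C)nc3ccccc23)cc1C(=O)OCCCC[Se]C#N` differs from compound 1 in one place: a group of 8 heavy atoms (5 carbon, 1 nitrogen, 1 oxygen, 1 selenium; no ring) in place of a group of 6 heavy atoms (3 carbon, 2 nitrogen, 1 selenium; no ring), on a carbonyl carbon. Among the measured compounds shown here, the only measured step that bears on this is the related one, which gave a 3.3-fold lower number from compound 1 to compound 2 (0.52 log units; beyond the scatter), where a chain one carbon longer entered on the same carbonyl carbon. A change of similar kind and modest size is therefore expected for compound 4, in the same direction, beyond the scatter but not by much. Compound 4 is estimated at 450 nM, within a range of 200 nM to 1000 nM, which would mean a step of a 2.6-fold lower number from compound 1 to compound 4 (0.41 log units; beyond the scatter).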

Compound 4, half-maximal inhibitory concentration: 1020 nM
Estimate against measurement, compound 4: 2.3-fold (0.36 log units) below, and the stated range ends below it.
By their numbers in this assay, from the lowest: compound 3; then compound 2; then compounds 4 and 1 (each within the scatter of the next).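

In this assay, the group of 8 heavy atoms in place of the group of 6 heavy atoms on the carbonyl carbon gives only a 1.1-fold lower number from compound 1 to compound 4 (0.06 log units; within the scatter), so turning the amide into an ester does not by itself move the number. Between the two esters, the shorter chain gives a 2.9-fold higher number from compound 2 to compound 4 (0.46 log units; beyond the scatter), which shows that this position responds to chain length. No evidence bearing on this result is available. Going by these compounds, it remains open whether a longer chain would lower the number further, and whether an amide carrying the longer ester's chain would do the same.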